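Methyl in place of methoxy and gut microsomal clearance

A few compounds are considered here, and "the series" means these few. Any claim that something is new, unique, unknown or untested is made for them only; others in the source may bear on it.

The measured compounds:
Compound 1 `COc1ccc(OC(F)(F)F)cc1Cn1c(C(=O)NCC(C)(C)CO)cc2cc(C#N)ccc21`: in an in vitro ADME assay on microsomes from Gut (Homo sapiens) for metabolic stability, using NADPH (on this read-out lower numbers stand for slow clearance and higher numbers for fast clearance), compound 1 gives < 6 mL.min-1.g-1, a limit of the assay.
Compound 2 `COc1ccc(Cl)cc1Cn1c(C(=O)NCC(C)(C)CO)cc2cc(C#N)ccc21`: in this assay compound 2 gives < 6 mL.min-1.g-1, likewise a limit.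
Compound 3 `COc1ccc(C)cc1Cn1c(C(=O)NCC(C)(C)CO)cc2cc(C#N)ccc21`: in this assay compound 3 gives < 6 mL.min-1.g-1, again a limit.

Compound 3 therefore stands at the limit shared by all three, (the limit of < 6 mL.min-1.g-1 in this assay, at which 3 of the 3 values shown sit). The steps a step that the two limits leave unreadable from compound 1 to compound 2, a step that the two limits leave unreadable from compound 1 to compound 3 and a step that the two limits leave unreadable from compound 2 to compound 3 are all unreadable, since each lies between two limits.

Compound 4 `Cc1ccc(C)c(Cn2c(C(=O)NCC(C)(C)CO)cc3cc(C#N)ccc32)c1` differs from compound 3 as follows: methyl in place of methoxy on an aromatic carbon. Going by the values given here, none of the measured steps changes this part of the structure, and none has a readable size, so they give no direction for the step in this assay. The expected step that the limit leaves unreadable from compound 3 to compound 4 is therefore estimated as small, with compound 4 most likely remaining at the same limit. Compound 4 is expected to give 5 mL.min-1.g-1 in this assay, with a range from 2 mL.min-1.g-1 to 14 mL.min-1.g-1.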

Compound 4, intrinsic clearance in microsomes: < 6 mL.min-1.g-1
Compound 4 gave a limit, no number; the forecaster's own chance of this, stated with the estimate: 60%; the middle value does not contradict the limit.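

Compound 4 also gives a limit in this assay, so the steps from compound 3 and from compound 2 to compound 4 cannot be read: the limit of < 6 mL.min-1.g-1 in this assay, at which 4 of the 4 values shown sit.

The compounds shown leave open whether methyl in place of methoxy changes intrinsic clearance at all, and how the four compounds compare with one another.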